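A Methyl Added to the Core of Compound 1

A few compounds are considered here, and "the series" means these few. Any claim that something is new, unique, unknown or untested is made for them only; others in the source may bear on it.

- compound 1 `COC(=O)C1=C(C)NC(C)=C(C(=O)OC)C1c1c(-c2cccs2)nc2sccn12` gives 110 nM
- compound 2 `COC(=O)C1=C(C)NC(C)=C(C(=O)OC)C1c1c(-c2cccnc2)nc2sccn12` gives 3550 nM
- compound 3 `COC(=O)C1=C(C)NC(C)=C(C(=O)OC)C1c1c(-c2c(Cl)csc2Cl)nc2sccn12` gives 180 nM

These values come from a functional assay on ileum (Cavia porcellus) for inhibition (on this read-out higher numbers stand for weaker inhibition and lower numbers for stronger inhibition), and the three compounds differ only in one aromatic group on a shared core. Compound 1 sits at the strong end of this small set, level with compound 3, as shown by the step of a 1.6-fold higher number from compound 1 to compound 3 (0.21 log units; within the scatter) between them. Compound 2 stands apart, with a 32-fold higher number from compound 1 to compound 2 (1.51 log units; beyond the scatter) as the step that separates it.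

Compound 4 `COC(=O)C1=C(C)NC(C)=C(C(=O)OC)C1c1c(-c2cccs2)nc2sc(C)cn12` keeps the thiophen-2-yl group of compound 1 and alters the core instead: methyl in place of hydrogen on an aromatic carbon. The methyl sits on an aromatic carbon of a five-membered aromatic ring with 1 nitrogen and 1 sulfur, next to the ring sulfur. Within the data shown here, no measured step touches this place, so the evidence is only indirect. The large step of a 32-fold higher number from compound 1 to compound 2 (1.51 log units; beyond the scatter) replaced a whole ring, which does not happen here. The closer comparison is a 1.6-fold higher number from compound 1 to compound 3 (0.21 log units; within the scatter), where a thiophene ring gained substituents with no change beyond the scatter. The expected change is a 1.3-fold higher number from compound 1 to compound 4 (0.10 log units; within the scatter) in this assay, which means no real step in either direction. Compound 4 is estimated at 140 nM, with an expected range of 45 nM to 450 nM.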

Compound 4, half-maximal inhibitory concentration: 1370 nM
Estimate against measurement, compound 4: 9.8-fold (0.99 log units) below; measured number above the stated range.
By their numbers in this assay, from the lowest: compounds 1 and 3 (each within the scatter of the next); then compound 4; then compound 2.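

In this assay, the step of a 12-fold higher number from compound 1 to compound 4 (1.10 log units; beyond the scatter) shows that this place on the shared core is sensitive: one methyl, a single carbon on an aromatic carbon next to the ring sulfur, clearly weakens inhibition. The earlier compounds shown here changed only the aromatic group on the other side of the molecule, and there size of change and size of effect did not go together, since a whole thiophene gaining two chlorine atoms gave only a 1.6-fold higher number from compound 1 to compound 3 (0.21 log units; within the scatter), while the large step of a 32-fold higher number from compound 1 to compound 2 (1.51 log units; beyond the scatter) needed a different ring altogether; compound 4 now shows that a large step can also come from the smallest of edits, made elsewhere on the molecule. The data shown offer no explanation of why this methyl weakens inhibition so much.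

On these data alone, only hydrogen and methyl appear at this place, so it stays open whether a fluorine atom, an ethyl group or an amine there would weaken inhibition as much, less or more. As far as these compounds go, it is also open whether the methyl would have the same effect alongside the pyridin-3-yl group of compound 2.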